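A few compounds are considered here, and "the series" means these few. Any claim that something is new, unique, unknown or untested is made for them only; others in the source may bear on it.

Measured compounds:
compound 1, `CCC(C)(C)Cc1c[nH]c(CCc2ccc(-c3cccc(C#N)n3)cc2)n1`: 95 nM
compound 2, `CCC(C)(C)Cc1c[nH]c(CCc2ccc(-c3ccc(F)cn3)cc2)n1`: 97 nM

Both numbers come from a functional assay on HEK293 cells for agonist activity at Bombesin receptor subtype-3 (Homo sapiens), read by luminescence and calcium flux, with a stated time of 10 min (a higher number here means that more compound is needed for the effect, a lower number that less compound is needed), where compound 1 gives 95 nM and compound 2 gives 97 nM; the two sit within the scatter of each other, so neither can be called the more potent. Among the measured compounds shown here, the only measured step, a 1.0-fold higher number from compound 1 to compound 2 (0.01 log units; within the scatter), swaps one substituent for another on the same six-membered ring that hangs off the shared core.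

Compound 3, `CCC(C)(C)Cc1c[nH]c(CCc2ccc(-n3cncn3)cc2)n1`, goes further: 1H-1,2,4-triazol-1-yl in place of 5-fluoropyridin-2-yl on an aromatic carbon. Here the whole attached ring is exchanged, not just a substituent on it, and the new ring is five-membered and attached through nitrogen. For the measured compounds named here, no measured step covers such an exchange, so the within-scatter result of the earlier step is only a weak guide.

Going by the values given here, with no direct precedent, the expected outcome for compound 3 is 300 nM, ranging from 70 nM to 1300 nM. This estimate corresponds to a step of a 3.1-fold higher number from compound 2 to compound 3 (0.49 log units; beyond the scatter), leaning toward a higher number.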

Compound 3, half-maximal effective concentration: 89 nM
The estimate for compound 3 lay 3.4-fold (0.53 log units) above the measured number, within the range that was stated.
By their numbers in this assay, from the lowest: compounds 3, 1 and 2 (each within the scatter of the next).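

In this assay, the position para to a large group accepts an exchange of the whole attached ring, not only a change of substituent on a six-membered ring (a 1.1-fold lower number from compound 2 to compound 3 (0.04 log units; within the scatter); a 1.1-fold lower number from compound 1 to compound 3 (0.03 log units; within the scatter)). The entering 1H-1,2,4-triazol-1-yl is a five-membered aromatic ring with 3 hetero atoms, yet both steps lie within the scatter, so this change gives no measurable separation from either pyridine compound. Nothing available here explains why these different rings give such similar numbers.

As far as these compounds go, all three compounds carry an aromatic ring at this position, so it remains open whether a ring is needed there at all, or whether an amine, a carboxylic acid or a longer chain would serve. From the compounds shown here alone, it also remains open whether a saturated ring such as morpholine would fit the same pattern.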